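Swapping the benzyl of compound 2 for a hydroxymethylcyclopentyl group

A few compounds are considered here, and "the series" means these few. Any claim that something is new, unique, unknown or untested is made for them only; others in the source may bear on it.

Compound 1 `C=CCn1c(=O)n(C2C=CC(CO)O2)c2nc(N)nc(O)c21`: 45%
Compound 2 `C=CCn1c(=O)n(Cc2ccccc2)c2nc(N)nc(O)c21`: 25%

In a functional assay on the whole organism (B cells) with Mus musculus as the target (on this read-out lower numbers stand for smaller maximal responses and higher numbers for larger maximal responses), compound 2 gives the lower of the two measured numbers, and its nearest neighbour compound 1 stands a step above it, as a number 20 percentage points lower from compound 1 to compound 2 (beyond the scatter) shows. Compound 3 `C=CCn1c(=O)n(C2CCC(CO)C2)c2nc(N)nc(O)c21` differs from compound 2 in one place: a group of 7 heavy atoms (6 carbon, 1 oxygen; one five-membered non-aromatic ring of carbon only) in place of a group of 7 heavy atoms (7 carbon; one six-membered aromatic ring of carbon only), on an aromatic nitrogen. Within the data shown here, the only step that bears on this change is the one from compound 1 to compound 2, where a non-aromatic five-membered ring carrying a hydroxymethyl was replaced by a benzyl and the maximal response fell beyond the scatter. Going back toward such a ring, compound 3 is expected to rise by a number 15 percentage points higher from compound 2 to compound 3 (beyond the scatter), to an estimated 40% (range 25% to 55%).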

Compound 3, largest response reached (reported as maximal response), in percent of the reference or control that the assay uses: 26%
Compound 3: the middle estimate sits 14 percentage points above what was measured, and the stated range covers the measured number.
By their numbers in this assay, from the lowest: compounds 2 and 3 (each within the scatter of the next); then compound 1.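

In this assay, replacing the benzyl with a hydroxymethylcyclopentyl group on the aromatic nitrogen gives a number 1 percentage points higher from compound 2 to compound 3 (within the scatter) and so does not separate the two groups. The larger response of compound 1 therefore does not follow from a non-aromatic five-membered ring with a hydroxymethyl alone: the all-carbon ring gives a number 19 percentage points lower from compound 1 to compound 3 (beyond the scatter) and remains level with benzyl. No evidence explains this difference between the two rings.

Still open, on these data alone, is whether the oxygen in the ring of compound 1 or its ring double bond accounts for the gap, and how an aminomethyl group in place of the hydroxymethyl would read out.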